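Acyl in Place of Methyl on a Weak Triazolopyrimidine Series

The source may report more compounds than this note shows. Statements on the series, on what has been measured and on what is new or still open speak of the compounds shown alone.

Of the compounds shown here, three built on one shared core have been measured in an assay on isolated protein for binding affinity to adenosine receptor A1 (Bos taurus); a higher number here means a weaker inhibitor, a lower number a stronger inhibitor. Compound 1, `CCCCCCNc1nc(-c2ccccc2)nc2c1nnn2Cc1ccccc1`, gives 13200000 nM. Compound 2, `CCCCNc1nc(-c2ccccc2)nc2c1nnn2Cc1ccccc1C(F)(F)F`, gives 6500000 nM. Compound 3, `CNc1nc(-c2ccccc2)nc2c1nnn2Cc1ccccc1F`, gives 25000000 nM, which is the highest of the three numbers. Its distance from compound 1 lies within the usual scatter of repeated measurements, so the two cannot be told apart on these data; its distance from compound 2 lies beyond that scatter, so compound 3 is the weaker binder of that pair. All three sit very far from the range of useful inhibitors.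

Compound 4, `COc1ccc(C(=O)Nc2nc(-c3ccccc3)nc3c2nnn3Cc2ccccc2F)cc1`, has not yet been measured in this assay. It differs from compound 3 in one place: (4-methoxyphenyl)carbonyl in place of methyl on a nitrogen on an aromatic ring. Among the compounds with values here, no measured pair in this set shows what such a replacement does, so any expectation rests on the general weakness of the three measured compounds and on the size of the group that enters. A step toward a lower number, beyond the scatter, is expected from compound 3 to compound 4, as a 5.0-fold lower number from compound 3 to compound 4 (0.70 log units; beyond the scatter). Compound 4 is therefore estimated at 5000000 nM, with a plausible range from 500000 nM to 30000000 nM.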

Compound 4, inhibition constant: 21900000 nM
Beside the measured number, compound 4's estimate is 4.4-fold (0.64 log units) below it, and the stated range covers the measured number.
By their numbers in this assay, from the lowest: compound 2; then compounds 1, 4 and 3 (each within the scatter of the next).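

In this assay, putting (4-methoxyphenyl)carbonyl in place of methyl on a nitrogen on an aromatic ring gives a 1.1-fold lower number from compound 3 to compound 4 (0.06 log units; within the scatter), so the two compounds cannot be told apart. Within the data shown here, this is the first pair here that differs in one place, and it shows that at this nitrogen a group of 10 heavy atoms, bringing a six-membered aromatic ring and a carbonyl, can replace a single carbon with no readable change in the number, while compound 4, at 21900000 nM, stays as far from useful inhibitors as the earlier compounds. Nothing available here explains why the number holds steady across so large a change in the group.

This single pair does not tell whether a smaller acyl group such as acetyl, or an amide carrying a carboxylic acid on its phenyl ring in place of the methoxy group, would move the number beyond the scatter. As far as these compounds go, compounds 1 and 2 differ from compound 3 in more than one place, so the separate contributions of a longer chain on this nitrogen and of the group on the benzyl ring also remain open.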